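Trimethoxyphenyl-bearing series: aryl replacement at the five-membered ring

The source may hold more compounds than are shown below. What is called first, only, known or untested is meant among the compounds shown, and "the series" means these compounds.

Measured so far:
compound 1 `COc1cc(-c2ccnc3cc(-c4cccc(C#N)c4)nn23)cc(OC)c1OC` — > 10000 nM
compound 2 `C=Cc1ccc(-c2cc3nccc(-c4cc(OC)c(OC)c(OC)c4)n3n2)cc1` — 193 nM

Compound 1 stands only at a limit in a functional assay on MCF7 cells (Homo sapiens) for inhibition, read by CCK-8 assay, with a stated time of 48 h; a lower number here means a stronger inhibitor, a higher number a weaker inhibitor; the value given for it is a boundary of the measurement, not a number (the limit of > 10000 nM in this assay, at which 1 of the 2 values shown sits). For the measured compounds named here, compound 2 is the one measured compound with a number, and it gives 193 nM in this assay.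

Compound 3 `COc1ccc(-c2cc3nccc(-c4cc(OC)c(OC)c(OC)c4)n3n2)cc1F` has not been measured in this assay. It differs from compound 1 as follows: 3-fluoro-4-methoxyphenyl in place of 3-cyanophenyl on an aromatic carbon. Going by the values given here, the one measured step that bears on this change is an at least 51-fold lower number from compound 1 to compound 2 (1.71 log units; beyond the scatter), where a different group also took the place of 3-cyanophenyl on the same aromatic carbon of the shared core. Both the 4-vinylphenyl of compound 2 and the 3-fluoro-4-methoxyphenyl of compound 3 replace the 3-cyanophenyl, so a step of comparable direction, downward in number and beyond the scatter, is expected for compound 3, though its size is uncertain given the limit on compound 1.

Compound 3 is therefore estimated at 400 nM in this assay, expected to lie between 100 nM and 3000 nM. The estimated step of an at least 25-fold lower number from compound 1 to compound 3 (1.39 log units; beyond the scatter) is expected to be large.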

Compound 3, half-maximal inhibitory concentration: 183 nM
Beside the measured number, compound 3's estimate is 2.2-fold (0.34 log units) above it, and the stated range covers the measured number.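

In this assay, a second replacement of the 3-cyanophenyl on this aromatic carbon of the five-membered ring gives an at least 54-fold lower number from compound 1 to compound 3 (1.73 log units; beyond the scatter) and so shows that the large shift seen with the 4-vinylphenyl is not confined to that one group. The two replacing groups cannot be told apart in this assay, with a 1.1-fold lower number from compound 2 to compound 3 (0.02 log units; within the scatter) despite their different substituents, so the vinyl group is not required for a number of this order within the compounds shown. Compound 1 stands at a limit rather than a number, so both its steps give only a minimum size: the limit of > 10000 nM in this assay, at which 1 of the 3 values shown sits.

The compounds shown leave open which feature of the 3-cyanophenyl goes with that limit, since an unsubstituted phenyl, a 4-cyanophenyl and a 3-methoxyphenyl would separate the nitrile itself from the place it holds on the ring. As far as these compounds go, it also remains open whether this aromatic carbon needs a phenyl ring at all or would keep a similar number with a morpholine, a short aliphatic amine or a carboxylic acid.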